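This account rests on a few compounds, and the source may have more. Where it says the series, first, only, none or still open, it means among the compounds named here.

For the measured compounds named here, in a functional assay on HepG2 cells (Homo sapiens) for cytotoxicity, read by MTT assay, with a stated time of 48 h (a higher number here means a weaker inhibitor, a lower number a stronger inhibitor), only two compounds built on the shared core have numbers so far. Compound 1 `[O-][n+]1nc(NCCO)[n+]([O-])c2ccccc21` gives 23200 nM, the higher of the two, while compound 2 `O=[N+]([O-])c1ccc(CNc2n[n+]([O-])c3ccccc3[n+]2[O-])cc1` gives 7700 nM, a gap beyond the usual scatter. Compound 3 `C=CCNc1n[n+]([O-])c2ccccc2[n+]1[O-]` has not yet been measured. It differs from compound 1 in one place: vinyl in place of hydroxymethyl on a saturated chain carbon bound to a nitrogen on an aromatic ring. This is vinyl in place of hydroxymethyl on a saturated chain carbon bound to a nitrogen on an aromatic ring, so 2-hydroxyethyl gives way to allyl. Going by the values given here, no measured pair isolates this change, so the expectation is loose. Compound 1 stands at the high end, and compound 2 at 7700 nM shows that lower numbers occur on this core. A modest move to a lower number in this assay is therefore expected, possibly no larger than the scatter. The estimated step is a 1.7-fold lower number from compound 1 to compound 3 (0.22 log units; within the scatter). For compound 3 the expected value is 14000 nM, within an estimated range of 6000 nM to 32000 nM.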

Compound 3, half-maximal inhibitory concentration: > 56000 nM
Compound 3 gave a limit, no number; the forecaster's own chance of this, stated with the estimate: 5%; middle value at least 4.0-fold (0.60 log units) from the limit.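

The result for compound 3 in this assay is a limit, not a number: the limit of > 56000 nM in this assay, at which 1 of the 3 values shown sits. Even so, the change from 2-hydroxyethyl to allyl gives an at least 2.4-fold higher number from compound 1 to compound 3 (0.38 log units; beyond the scatter), which shows that this position responds to the swap and that the response runs towards a higher number, something no earlier pair could show. The swap removes the oxygen and brings in a double bond at once, so the compounds shown cannot separate the two.

From the compounds shown here alone, how far the true value of compound 3 lies past its limit remains open. Also open, going by these compounds, is whether a plain propyl chain, with neither oxygen nor double bond, or a 2-aminoethyl chain carrying an amine, would fall nearer compound 1 or compound 3.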